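Compound 1 to compound 4: a triazole for a pyrazole

This account rests on a few compounds, and the source may have more. Where it says the series, first, only, none or still open, it means among the compounds named here.

- compound 1 `Cc1cc(-n2cccn2)cc(C(=O)NNS(=O)(=O)c2ccccc2)c1F` gives 6.3 ug/mL
- compound 2 `CC(C)Oc1cccc(C(=O)NNS(=O)(=O)c2ccccc2F)c1` gives 50 ug/mL
- compound 3 `Cc1cc(C(=O)NNS(=O)(=O)c2ccccc2F)cc(-c2ccco2)c1` gives 6.3 ug/mL

All three values come from a physicochemical assay for solubility, read by nephelometry, measured as kinetic solubility, at pH 2; on this read-out higher numbers stand for higher solubility and lower numbers for lower solubility. Compound 1 stands level with compound 3 within the scatter, and compound 2 is clearly higher than both.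

The next compound is compound 4 `Cc1cc(-n2nccn2)cc(C(=O)NNS(=O)(=O)c2ccccc2)c1F`, in which 2H-1,2,3-triazol-2-yl takes the place of 1H-pyrazol-1-yl on an aromatic carbon of the core of compound 1 (2H-1,2,3-triazol-2-yl in place of 1H-pyrazol-1-yl on an aromatic carbon). For the measured compounds named here, no measured pair in this small set isolates that exchange, so there is no direct precedent for its size. Going by the values given here, compound 3, which also carries one five-membered aromatic ring, gives 6.3 ug/mL, and that is the only nearby guide. In this assay no step beyond the scatter is expected, with at most a slight rise. The expected change is a 1.1-fold higher number from compound 1 to compound 4 (0.05 log units; within the scatter). Compound 4 is estimated at 7 ug/mL, with an expected range of 3 ug/mL to 20 ug/mL.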

Compound 4, solubility: 25 ug/mL
Estimate against measurement, compound 4: 3.6-fold (0.55 log units) below; measured number outside the range, above it.
By their numbers in this assay, from the lowest: compounds 1 and 3 (each within the scatter of the next); then compounds 4 and 2 (each within the scatter of the next).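

In this assay, for the compounds shown here, the exchange of 1H-pyrazol-1-yl for 2H-1,2,3-triazol-2-yl on this aromatic carbon gives a 4.0-fold higher number from compound 1 to compound 4 (0.60 log units; beyond the scatter) and is the first one-place comparison. The two groups have the same count of heavy atoms, each is one five-membered aromatic ring with no net charge, and they differ by one ring carbon replaced by nitrogen; in this pair, that exchange alone moves the read-out beyond the scatter. No measured evidence on the compounds accounts for the rise.

A single pair leaves open whether the exchange would give a step of similar size on another core. Also open, as far as these compounds go, is how this position responds to a group of a different kind, such as an amine or a carboxylic acid on the same aromatic carbon.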